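Replacing 4-(trifluoromethyl)phenyl with 1,3-thiazol-2-yl

The compounds below may be only part of what the source reports. "The series", "measured", "known", "first", "only" and "open" are said of these compounds alone.

Of the compounds shown here, two that share a core have been measured so far in an ADME assay on microsomes from liver (Mus musculus) for metabolic stability, read by LC-MS, with NADPH named in the record, with a stated time of 60 min, tested at 1 uM, in the absence of a further agent (on this read-out lower numbers stand for a less stable compound and higher numbers for a more stable compound), and both sit at the same reporting limit. Compound 1 `COc1cc(-c2c(C)nc3c(N4CC[C@@H](NC(C)=O)C4)cc(C)nn23)cc(OC)c1OC` gives > 95% as its result, which is a limit of the assay and not a number. Compound 2 `CC(=O)N[C@@H]1CCN(c2cc(C)nn3c(-c4ccc(C(F)(F)F)cc4)c(C)nc23)C1` gives > 95% as its result, and this too is only a limit. Together they show the limit of > 95% in this assay, at which 2 of the 2 values shown sit, and nothing finer.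

Compound 3 `CC(=O)N[C@@H]1CCN(c2cc(C)nn3c(-c4nccs4)c(C)nc23)C1` has not yet been measured. It keeps the core of compound 2 but carries 1,3-thiazol-2-yl in place of 4-(trifluoromethyl)phenyl on an aromatic carbon. Among the compounds with values here, no measured pair of compounds differing in one place is available, so the size of this change cannot be read from the data. With compound 2 at > 95% on this read-out, there is little room to rise, so a small fall or none beyond the scatter is expected. In numbers, the expected change is a number at least 5 percentage points lower from compound 2 to compound 3 (that floor lies within the scatter) on this estimate. For compound 3 the expected value is 90% with a range from 70% to 100% on this estimate.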

Compound 3, percent of the compound remaining: > 95%
Compound 3: a limit, no number; the forecaster's own chance of this, stated with the estimate: 40%; middle value at least 5 percentage points from the limit.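

In this assay compound 3 gives > 95%, which is a limit of the assay and not a number. Compound 2 also stands at a limit, so no step from it to compound 3 can be read: the limit of > 95% in this assay, at which 3 of the 3 values shown sit.

The compounds shown leave open whether 1,3-thiazol-2-yl in place of 4-(trifluoromethyl)phenyl changes the percent of compound remaining at all.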